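Two limits in a halophenyl series, one swap to read

A few compounds are considered here, and "the series" means these few. Any claim that something is new, unique, unknown or untested is made for them only; others in the source may bear on it.

Compound 1 is `Fc1cccc(Nc2nc(-c3cccc(F)c3)nc3ccc(F)cc23)c1`. In a functional assay on COLO 205 cells (Homo sapiens) for cytotoxicity, read by MTT assay, with a stated time of 48 h (a lower number here means a stronger inhibitor, a higher number a weaker inhibitor), compound 1 gives > 50000 nM, which is a limit of the assay rather than a number.
Compound 2 is `Fc1cccc(-c2nc(Nc3ccccc3Cl)c3cc(F)ccc3n2)c1`. In this assay compound 2 gives > 50000 nM, again a limit and not a number.

Compound 2 therefore stands only at a limit, as does every value shown; both sit at the limit of > 50000 nM in this assay, at which 2 of the 2 values shown sit. Going by the values given here, the single step between measured compounds, a step that the two limits leave unreadable from compound 1 to compound 2, is unreadable because the limit of > 50000 nM in this assay, at which 2 of the 2 values shown sit, bounds both ends.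

Compound 3 is `Fc1cccc(-c2nc(Nc3cccc(Br)c3)c3cc(F)ccc3n2)c1`. Its change from compound 2 is 3-bromophenyl in place of 2-chlorophenyl on a nitrogen on an aromatic ring.

No measured step bears on this change: the one step shown has no readable size, so no direction can be taken from it. With both measured values at the limit, the expectation for compound 3 is that a number no higher from compound 2 to compound 3 (the limit leaves the size open) shows nothing beyond scatter and that the assay most likely again reports a limit. Compound 3 is estimated at 50000 nM, expected between 20000 nM and 200000 nM.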

Compound 3, half-maximal inhibitory concentration: > 50000 nM
Compound 3 was reported as a limit; the forecaster's own chance of this, stated with the estimate: 80%; the middle value lies on the limit itself.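

No new step can be read between compound 1, compound 2 and compound 3 in this assay, since all three stand at a limit of the assay and not at a number: the limit of > 50000 nM in this assay, at which 3 of the 3 values shown sit. The compounds shown leave open whether any of these halophenyl swaps on the shared core changes cytotoxicity at all.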